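Methyl for chloro: from compound 1 to compound 3

This account rests on a few compounds, and the source may have more. Where it says the series, first, only, none or still open, it means among the compounds named here.

Within the data shown here, compound 1 `Cc1cccc(C(=O)N(C(=S)OCCN2C(=O)c3ccccc3C2=O)c2ccc(Cl)cc2)c1` gives 58000 nM in an ADME assay on MT4 cells (Homo sapiens) for cytotoxicity, read by MTT assay (on this read-out lower numbers stand for higher toxicity in this test and higher numbers for lower toxicity in this test), the higher of the two numbers measured so far. Compound 2 `O=C1c2ccccc2C(=O)N1CCOC(=S)N(C(=O)c1ccc(C(F)(F)F)cc1)c1ccc(Cl)cc1` gives 10000 nM in this assay. Among the measured compounds shown here, the one measured step, a 5.8-fold lower number from compound 1 to compound 2 (0.76 log units; beyond the scatter), altered the group on the carbonyl carbon, not the ring changed here. Compound 3 `Cc1ccc(N(C(=O)c2cccc(C)c2)C(=S)OCCN2C(=O)c3ccccc3C2=O)cc1` differs from compound 1 by methyl in place of chloro on an aromatic carbon. For the measured compounds named here, no measured step touches this ring, so no movement beyond the scatter is expected. The estimated step is a 1.2-fold lower number from compound 1 to compound 3 (0.06 log units; within the scatter). Compound 3 is therefore estimated at 50000 nM in this assay, with a range of 20000 nM to 120000 nM.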

Compound 3, half-maximal cytotoxic concentration: > 100000 nM
Compound 3 gave a limit, no number; the forecaster's own chance of this, stated with the estimate: 15%; at least 2.0-fold (0.30 log units) between middle value and limit.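

Compound 3 gives a limit and not a number: the limit of > 100000 nM in this assay, at which 1 of the 3 values shown sits.
Among these compounds, this is the first reading on the aromatic ring that carries chloro in compound 1, and methyl in place of chloro gives an at least 1.7-fold higher number from compound 1 to compound 3 (0.23 log units; that floor lies within the scatter) in this assay. As far as these compounds go, the floor of this step therefore does not separate the two compounds beyond the scatter, and the true size of the step stays unknown.
From the compounds shown here alone, how an amine or a carboxylic acid in place of chloro on this carbon would read stays open. So does whether the change carries over with the 4-(trifluoromethyl)phenyl group of compound 2 on the carbonyl carbon.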